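The source may hold more compounds than are shown below. What is called first, only, known or untested is meant among the compounds shown, and "the series" means these compounds.

Going by the values given here, in a functional assay on MCF7 cells (Homo sapiens) for antiproliferative activity, read by MTT assay, with a stated time of 72 h (a lower number here means a stronger inhibitor, a higher number a weaker inhibitor), compound 1 `O=C(COc1ccc(C(=O)/C=C/c2cccc(Cl)c2)cc1)N[C@H]1CCOC1=O` gives 20900 nM, and it is the only one of the three compounds tested so far to return an actual number. Compound 2 `O=C1OCC[C@@H]1NC(=S)SCCOc1cccc2ccccc12` reads > 64000 nM, which is a limit of the assay and not a number. Compound 3 `O=C(CNc1cccc(Cl)c1)N[C@H]1CCOC1=O` reads > 64000 nM, which is likewise a limit.

The next compound to be tested, compound 4 `O=C(COc1ccc(C(=O)/C=C/c2cccc(Br)c2)cc1)N[C@H]1CCOC1=O`, keeps the core of compound 1 and differs from it in one place: bromo in place of chloro on an aromatic carbon. The change sits meta to a large group and turns 3-chlorophenyl into 3-bromophenyl. Everything else in the structure stays the same.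

Among the compounds with values here, no pair of compounds measured so far shows what this swap does in this assay, so its effect cannot be read directly from the data. With compound 1 at 20900 nM as the only numerical anchor, no step beyond the usual scatter is expected, in either direction. The estimated change is a 1.1-fold lower number from compound 1 to compound 4 (0.04 log units; within the scatter), which would be too small to tell apart from repeat-to-repeat variation. For compound 4 the expected value is 19000 nM, with an estimated range of 9000 nM to 40000 nM.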

Compound 4, half-maximal inhibitory concentration: 28300 nM
Beside the measured number, compound 4's estimate is 1.5-fold (0.17 log units) below it; the measured number falls inside the stated range.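

Going by these compounds alone, this is the first step that can be read at this position, on the aromatic ring at the far end of compound 1: in this assay, bromo in place of chloro gives a 1.4-fold higher number from compound 1 to compound 4 (0.13 log units; within the scatter). Compound 1 and compound 4 therefore cannot be told apart in this read-out, and as far as this pair shows, the assay does not distinguish the two halogens at this spot. Compound 2 and compound 3 each sit at a limit and not at a number, so this pair is the only one that can be compared on actual numbers: the limit of > 64000 nM in this assay, at which 2 of the 4 values shown sit.

On these data alone, both groups in this pair are halogens, so it remains open whether a group of a different kind at the same position, such as an amine or a carboxylic acid, would shift the number beyond the usual scatter. As far as these compounds go, it also remains open whether the bromo or chloro group matters at all, a question that compound 1 and compound 4 cannot answer without a partner carrying plain hydrogen at that carbon.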